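Chloro in place of hydrogen on compound 3

The source may report more compounds than this note shows. Statements on the series, on what has been measured and on what is new or still open speak of the compounds shown alone.

In a functional assay on SF-539 cells (Homo sapiens) for inhibition, read by sulforhodamine B assay, with a stated time of 48 h (on this read-out lower numbers stand for stronger inhibition of growth and higher numbers for weaker inhibition of growth), compound 1 (`Cc1ccc(NC(=O)/C=C/c2ccccc2)c(C(N)=O)c1`) gives 2050 nM and compound 2 (`NC(=O)c1cc(Br)ccc1NC(=O)/C=C/c1ccccc1`) gives 819 nM while compound 3 (`NC(=O)c1cc(I)ccc1NC(=O)/C=C/c1ccccc1`) gives 445 nM and so stands level with compound 2 and clear of compound 1. Compound 4 (`NC(=O)c1cc(I)ccc1NC(=O)/C=C/c1ccccc1Cl`) carries chloro in place of hydrogen on an aromatic carbon, which turns phenyl into 2-chlorophenyl. The measured steps all changed a different place. Two are modest, a 2.5-fold lower number from compound 1 to compound 2 (0.40 log units; beyond the scatter) and a 4.6-fold lower number from compound 1 to compound 3 (0.66 log units; beyond the scatter) in size, and the third, a 1.8-fold lower number from compound 2 to compound 3 (0.26 log units; within the scatter) in size, stays within the scatter. Within the data shown here, no measured compound shows a change on this phenyl, so no step beyond the scatter is expected. The expected step is a 1.1-fold lower number from compound 3 to compound 4 (0.05 log units; within the scatter) as an estimate. For compound 4 the estimated value is 400 nM with an expected range from 140 nM to 1150 nM at this stage.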

Compound 4, concentration for 50% growth inhibition: 444 nM
Compound 4: middle estimate off by 1.1-fold (0.05 log units), on the low side, and the stated range covers the measured number.
By their numbers in this assay, from the lowest: compounds 4, 3 and 2 (each within the scatter of the next); then compound 1.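

Among these compounds, this is the first reading on the phenyl, since the earlier steps all changed a different place. In this assay, replacing hydrogen with chloro gives a 1.0-fold lower number from compound 3 to compound 4 (0.00 log units; within the scatter), so this position, ortho to a large group, takes a chlorine without a difference that can be read in growth inhibition. No measurement here offers an explanation for this result. Still open, on these data alone, is whether an amine or a carboxylic acid at this position would also leave the number level, and whether the chloro would do so elsewhere on the same ring.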